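The source may hold more compounds than are shown below. What is called first, only, known or untested is meant among the compounds shown, and "the series" means these compounds.

In an assay on isolated protein (Cavia porcellus) with Sigma non-opioid intracellular receptor 1 (Homo sapiens) as the target, read by radioligand binding (on this read-out lower numbers stand for stronger inhibition and higher numbers for weaker inhibition), compound 2 `CN(C)CCCCCCCCOc1ccc2oc(-c3ccccc3)cc(=O)c2c1` gives 143 nM. Compound 1 `O=c1cc(-c2ccccc2)oc2cccc(OCCCN3CCC(O)CC3)c12` gives 91 nM in this assay, and the two numbers lie within the scatter of each other. Compound 3 `O=c1cc(-c2ccccc2)oc2ccc(OCCCCCCN3CCCC(O)C3)cc12` has not yet been measured. It differs from compound 2 by 3-hydroxypiperidin-1-yl in place of 2-(dimethylamino)ethyl on a saturated chain carbon, six bonds along the chain from an oxygen on an aromatic ring. The entering hydroxypiperidine ring is also present in compound 1, whose value 91 nM sits close to that of compound 2. The step expected from compound 2 to compound 3 is a 1.4-fold lower number from compound 2 to compound 3 (0.16 log units; within the scatter), nothing beyond the scatter. Compound 3 is estimated at 100 nM, with a range from 40 nM to 250 nM.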

Compound 3, half-maximal inhibitory concentration: 77 nM
The estimate for compound 3 lay 1.3-fold (0.11 log units) above the measured number; the measured number falls inside the stated range.
By their numbers in this assay, from the lowest: compounds 3, 1 and 2 (each within the scatter of the next).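

Replacing the 2-(dimethylamino)ethyl with 3-hydroxypiperidin-1-yl at this place on the chain gives a 1.9-fold lower number from compound 2 to compound 3 (0.27 log units; within the scatter) in this assay and so shows that this position accepts a ring carrying a hydroxyl without a change beyond the scatter. The larger group, with its added hydrogen-bond donor, leaves the reading about where it was. Nothing measured here offers an explanation for this result. Still open, going by these compounds, is whether a plain piperidine or a morpholine at this place would read the same. A longer chain carrying the same 3-hydroxypiperidin-1-yl is also untested among the compounds shown here.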